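Removing the Allyl Group: Expected Cytotoxicity of Compound 4

The source may hold more compounds than are shown below. What is called first, only, known or untested is meant among the compounds shown, and "the series" means these compounds.

Compound 1, `CC(=O)OC1=CC(=O)C2=C(C1=O)[C@]13CCC[C@](C)(C(=O)OC1)[C@@H]3C=C2`: in an ADME assay on Vero cells (Chlorocebus sabaeus) for cytotoxicity, read by microscopy, with a stated time of 24 h, tested at 10 ug/mL (a lower number here means a stronger effect, a higher number a weaker effect of the compound at the concentration tested), compound 1 gives 92.4%.
Compound 2, `C[C@@]12CCC[C@]3(COC1=O)C1=C(C=C[C@H]32)C(=O)C=C(O[Si](C)(C)C)C1=O`: compound 2 gives 83.6%.
Compound 3, `C=CCOC1=CC(=O)C2=C(C1=O)[C@]13CCC[C@](C)(C(=O)OC1)[C@@H]3C=C2`: compound 3 gives 85.5%.

For the measured compounds named here, compound 3 stands second highest of the three numbers measured so far. Its nearest neighbour is compound 2, and the step of a number 1.9 percentage points higher from compound 2 to compound 3 (within the scatter) lies within the scatter; the furthest is compound 1, and the step of a number 6.9 percentage points lower from compound 1 to compound 3 (within the scatter) is also within the scatter. In short, the three compounds cannot be told apart on these numbers.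

Compound 4, `C[C@@]12CCC[C@]3(COC1=O)C1=C(C=C[C@H]32)C(=O)C=C(O)C1=O`, differs from compound 3 in one place: hydrogen in place of allyl on an oxygen on an unsaturated carbon. Cut one bond further out, the change reads allyloxy to hydroxy.

Going by the values given here, every measured step so far swaps the group on this same oxygen on an unsaturated carbon: a number 8.8 percentage points lower from compound 1 to compound 2 (within the scatter), a number 6.9 percentage points lower from compound 1 to compound 3 (within the scatter) and a number 1.9 percentage points higher from compound 2 to compound 3 (within the scatter), each within the scatter. Nothing measured points to a group on this oxygen moving the number in this assay beyond the scatter, so the step of a number 0.5 percentage points higher from compound 3 to compound 4 (within the scatter) is expected to stay within it. A hydrogen on this oxygen has not been measured before, so the range is set somewhat wider. Compound 4 is therefore estimated at 86%, with a range from 72% to 98%.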

Compound 4, a percentage reported as activity, at one concentration (the size of the read-out at that concentration, not a potency): 88.4%
Beside the measured number, compound 4's estimate is 2.4 percentage points below it; the range from low to high includes it.
By their numbers in this assay, from the lowest: compounds 2, 3, 4 and 1 (each within the scatter of the next).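

Hydrogen on this oxygen on an unsaturated carbon is the first case here where the oxygen carries no added group at all, and in this assay the change still does not separate the compounds: there is a number 2.9 percentage points higher from compound 3 to compound 4 (within the scatter) when allyl gives way to hydrogen, a number 4.8 percentage points higher from compound 2 to compound 4 (within the scatter) when the silicon-bearing group does, and a number 4 percentage points lower from compound 1 to compound 4 (within the scatter) when acetyl does. For the compounds shown here, the earlier compounds compared only one added group with another, whereas this result shows that allyloxy to hydroxy, a change that removes the whole group, also leaves all four compounds indistinguishable in this read-out. No measurement available here accounts for this outcome.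

Still open, from the compounds shown here alone, is whether a different kind of group on this oxygen, such as a longer chain, an amine or a carboxylic acid, would move the number beyond the usual scatter. These four compounds also vary only this one place, so they leave unanswered how this assay would respond to changes elsewhere on the shared core.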